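The source may hold more compounds than are shown below. What is called first, only, known or untested is meant among the compounds shown, and "the series" means these compounds.

Measured so far:
compound 1 `CCN1CC[C@@]2(OC)OC(N)=C(C#N)[C@@H](c3ccccc3)[C@@H]2C1`: 23400 nM
compound 2 `CCCN1CC[C@@]2(OC)OC(N)=C(C#N)[C@@H](c3ccccc3)[C@@H]2C1`: 20700 nM
compound 3 `CO[C@@]12CCN(C)C[C@H]1[C@H](c1ccc(Br)cc1)C(C#N)=C(N)O2`: 7900 nM

All three were tested in a functional assay on trachea (Cavia porcellus); a lower number here means a stronger inhibitor, a higher number a weaker inhibitor. Compound 1 and compound 2 share one core; compound 3 has a different core, and the difference between the two cores is not broken down here. Compound 3 gives the lowest of the three numbers, and its gap to compound 2 and to compound 1 lies beyond the scatter of repeated measurements, so it is the strongest inhibitor of the three in this assay.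

Compound 2 differs from compound 1 by methyl in place of hydrogen on a saturated chain carbon, two bonds along the chain from an amine nitrogen in a ring. This change gave a 1.1-fold lower number from compound 1 to compound 2 (0.05 log units; within the scatter), a step that does not exceed the scatter, so the two compounds cannot be told apart in this assay.

Compound 4 `CCN1CC[C@@]2(OC)OC(N)=C(C#N)[C@@H](c3ccc(Br)cc3)[C@@H]2C1` has not yet been measured. It differs from compound 3 by methyl in place of hydrogen on a saturated chain carbon bound to an amine nitrogen in a ring. Going by the values given here, this is the same kind of change as the one from compound 1 to compound 2, but not the same one: in compound 2 the methyl enters two bonds along the chain from the amine nitrogen in the ring, whereas in compound 4 it enters on the saturated chain carbon bound to that nitrogen. Because the earlier step of this kind was a 1.1-fold lower number from compound 1 to compound 2 (0.05 log units; within the scatter), a similarly small step is expected here, a 1.1-fold lower number from compound 3 to compound 4 (0.05 log units; within the scatter). Compound 4 is therefore estimated to give about 7000 nM in this assay, most likely between 3000 nM and 16000 nM.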

Compound 4, half-maximal inhibitory concentration: 13200 nM
Beside the measured number, compound 4's estimate is 1.9-fold (0.28 log units) below it; the measured number falls inside the stated range.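

In this assay, methyl in place of hydrogen on a saturated chain carbon bound to an amine nitrogen in a ring gave a 1.7-fold higher number from compound 3 to compound 4 (0.22 log units; within the scatter), and bromo in place of hydrogen on an aromatic carbon gave a 1.8-fold lower number from compound 1 to compound 4 (0.25 log units; within the scatter), so neither single change moves the number beyond the scatter. Set beside the earlier chain step, the new chain step gives no sign that adding methyl behaves differently on the two cores: the same change on two cores in this assay, a 1.1-fold lower number (0.05 log units; within the scatter) from compound 1 to compound 2 and a 1.7-fold higher number (0.22 log units; within the scatter) from compound 3 to compound 4, 1.9-fold (0.28 log units) apart, within the scatter of two such steps. This does not prove that the change carries over unaltered: each core offers a single pair, the methyl enters at a different place on the chain in the two steps, and a true difference smaller than the scatter would go unseen.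

The chains shown are short, so it remains open whether a longer chain such as butyl, or a chain ending in a hydroxyl group or a carboxylic acid, would give a step beyond the scatter. On the aromatic ring only hydrogen and bromo appear, which leaves open what chloro or methoxy in place of bromo would do to the number.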